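A few compounds are considered here, and "the series" means these few. Any claim that something is new, unique, unknown or untested is made for them only; others in the source may bear on it.

Measured in a functional assay on MCF7 cells (Homo sapiens) for cytotoxicity, with a stated time of 48 h; a higher number here means a weaker inhibitor, a lower number a stronger inhibitor:
Compound 1 `COc1cc(OC)c(C(=O)/C=C/c2ccccc2OC)c(OC)c1` gives 8900 nM
Compound 2 `COc1cc(OC)c(C(=O)/C=C/c2ccccc2)c(OC)c1` gives 9400 nM
Compound 3 `COc1cc(OC)c(C(=O)/C=C/c2ccc(Cl)cc2)c(OC)c1` gives 7500 nM

Compound 3 cannot be told apart from the other two, since the measured steps are a 1.2-fold lower number from compound 1 to compound 3 (0.07 log units; within the scatter) and a 1.3-fold lower number from compound 2 to compound 3 (0.10 log units; within the scatter) and both stay small. The same holds for a 1.1-fold higher number from compound 1 to compound 2 (0.02 log units; within the scatter) where hydrogen takes the place of methoxy.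

The next compound is compound 4 `COc1cc(OC)c(C(=O)/C=C/c2ccc(Br)cc2)c(OC)c1`, with bromo in place of chloro on an aromatic carbon. Among the measured compounds shown here, no measured step swaps one halogen for another, so the closest guide is the chloro in place of hydrogen step into compound 3, which was within the scatter.

The expected change in this assay is a 1.0-fold lower number from compound 3 to compound 4 (0.02 log units; within the scatter) and thus none beyond the scatter. Compound 4 is estimated at 7200 nM with an expected range from 4000 nM to 12000 nM in this series.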

Compound 4, half-maximal inhibitory concentration: 9500 nM
For compound 4 the middle estimate is 1.3-fold (0.12 log units) below the measured one; the measured number falls inside the stated range.
By their numbers in this assay, from the lowest: compounds 3, 1, 2 and 4 (each within the scatter of the next).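

At this position, on an aromatic carbon para to a large group, bromo and chloro cannot be told apart in this assay (a 1.3-fold higher number from compound 3 to compound 4 (0.10 log units; within the scatter)). Bromo is equally indistinguishable from hydrogen (a 1.0-fold higher number from compound 2 to compound 4 (0.00 log units; within the scatter)) and from the 2-methoxyphenyl arrangement (a 1.1-fold higher number from compound 1 to compound 4 (0.03 log units; within the scatter)), so all four compounds stay level within the scatter. Nothing available gives any further insight into this flat result.

Still open, going by these compounds, is whether an amine or a carboxylic acid at this position would stand apart from these compounds. Also open, on these data alone, is how changing the methoxy groups on the shared core would read in this assay.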